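Piperidinyl-piperidine sulfonamides: cytotoxicity screen, compound 1 to compound 4

This account rests on a few compounds, and the source may have more. Where it says the series, first, only, none or still open, it means among the compounds named here.

Measured compounds and values in an ADME assay on HCT-116 cells (Homo sapiens) for cytotoxicity, read by CellTiter-Glo, with a stated time of 72 h; on this read-out higher numbers stand for weaker inhibition and lower numbers for stronger inhibition:
- compound 1 `Cc1cc(C)c(S(=O)(=O)N2CCC(N3CCC(O)CC3)CC2)c(C)c1`: > 5000 nM
- compound 2 `CC1CCN(C2CCN(S(=O)(=O)c3cnc(Cl)s3)CC2)CC1`: > 10000 nM
- compound 3 `CC1CCN(C2CCN(S(=O)(=O)c3ccccc3-c3ccccc3)CC2)CC1`: > 5000 nM

All three values are limits of this assay rather than numbers. For compound 1 the value > 5000 nM is a limit, at which two of the three values sit (the limit of > 5000 nM in this assay, at which 2 of the 3 values shown sit). For compound 2 the value > 10000 nM is also a limit, the one at which one of the three values sits (the limit of > 10000 nM in this assay, at which 1 of the 3 values shown sits). For the measured compounds named here, since each value is only a limit, no ordering among compounds 1, 2 and 3 can be read from this assay, and no step between measured compounds is available.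

Compound 4 `Cc1cc(C)c(S(=O)(=O)N2CCC(N3CCC(C)OC3)CC2)c(C)c1` is not yet measured. It differs from compound 1 by the change (a group of 7 heavy atoms (5 carbon, 1 nitrogen, 1 oxygen; one six-membered non-aromatic ring with 2 hetero atoms) in place of a group of 7 heavy atoms (5 carbon, 1 nitrogen, 1 oxygen; one six-membered non-aromatic ring with 1 hetero atom), on a saturated ring carbon).

With the core of compound 1 kept and compound 1 itself giving only a limit, the expectation for compound 4 is no step beyond the scatter in this assay; the step from compound 1 to compound 4 is estimated at a step that the limit leaves unreadable from compound 1 to compound 4. Compound 4 is therefore expected to give about 8000 nM, within a range of 3000 nM to 30000 nM, and most probably to be reported again only as a limit.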

Compound 4, half-maximal inhibitory concentration: > 5000 nM
Compound 4: no number, only a limit; the forecaster's own chance of this, stated with the estimate: 85%; the middle value is on the limit's open side.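

In this assay compound 4 gives > 5000 nM, which is a limit and not a number. For the compounds shown here, compound 1 also stands only at a limit, so no step from compound 1 to compound 4 can be read. The compounds shown leave open whether any member of this series gives a measurable value in this assay.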